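The source may report more compounds than this note shows. Statements on the series, on what has been measured and on what is new or still open speak of the compounds shown alone.

Series notes. The shared core is kept throughout, and the compounds differ only in the group on the amine nitrogen of the six-membered non-aromatic ring with two nitrogen. In an assay on CHO cells for displacement of a labelled ligand from adenosine receptor A3 (Homo sapiens), read by scintillation counting, with a stated time of 45 min, in the presence of a further agent that is not named here (a higher number here means a weaker inhibitor, a lower number a stronger inhibitor), compound 1 `CCCn1c(=O)[nH]c2nc(-c3ccc(S(=O)(=O)N4CCN(c5ccc(F)cc5)CC4)cc3)[nH]c2c1=O` reaches only the limit of the assay, > 1000 nM. Compound 2 `CCCn1c(=O)[nH]c2nc(-c3ccc(S(=O)(=O)N4CCN(c5cccc(Cl)c5)CC4)cc3)[nH]c2c1=O` gives 53.5 nM in this assay. Compound 3 `CCCn1c(=O)[nH]c2nc(-c3ccc(S(=O)(=O)N4CCN(c5ccccc5F)CC4)cc3)[nH]c2c1=O` likewise sits at a limit in this assay, > 1000 nM, which is not a number. Of the measured steps, an at least 18-fold lower number from compound 1 to compound 2 (1.27 log units; beyond the scatter) and an at least 18-fold higher number from compound 2 to compound 3 (1.27 log units; beyond the scatter) are large, whereas a step that the two limits leave unreadable from compound 1 to compound 3. Given (the limit of > 1000 nM in this assay, at which 2 of the 3 values shown sit), compound 3 can only be placed at the weak end of the series without a number of its own.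

Compound 4 `CCCn1c(=O)[nH]c2nc(-c3ccc(S(=O)(=O)N4CCN(Cc5ccc(Br)c(F)c5)CC4)cc3)[nH]c2c1=O` differs from compound 3 in one place: 4-bromo-3-fluorobenzyl in place of 2-fluorophenyl on an amine nitrogen in a ring. Within the data shown here, none of the measured steps puts a benzyl group on that nitrogen, so no step of the same kind is available. Among the measured compounds shown here, the one number belongs to compound 2, and the two limits show that changes to the aryl group on this nitrogen move values across the limit. Compound 4 is therefore expected to fall between the limit and the region of compound 2. The step from compound 3 to compound 4 in this assay is estimated as an at least 1.6-fold lower number from compound 3 to compound 4 (0.22 log units; that floor lies within the scatter). The estimate for compound 4 in this assay is 600 nM, in a range from 80 nM to 5000 nM, with a sizeable chance that only a limit is reported again.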

Compound 4, inhibition constant: > 1000 nM
Compound 4 ended at the assay's limit (the forecaster's own chance of this, stated with the estimate: 45%); middle value at least 1.6-fold (0.22 log units) away from the limit.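

Compound 4 is the only compound shown with a benzyl group on the amine nitrogen in a ring, and in this assay this 4-bromo-3-fluorobenzyl group adds no second number to the series, leaving compound 2 as the only one with a measured value. Among these compounds, the one readable step is an at least 18-fold higher number from compound 2 to compound 4 (1.27 log units; beyond the scatter), so this benzyl group joins 2-fluorophenyl and 4-fluorophenyl on the far side of the limit from 3-chlorophenyl. The steps to compound 4 from compound 3 and from compound 1 cannot be read, because both ends of each step are limits: the limit of > 1000 nM in this assay, at which 3 of the 4 values shown sit.

On these data alone, how far compound 1, compound 3 and compound 4 lie past that limit stays open, as does whether the step from compound 2 to compound 4 belongs to the benzyl group itself or to the bromine and fluorine on its ring. Unsubstituted benzyl and 3-chlorobenzyl on the same nitrogen are not among the compounds shown, and either would bear directly on that question.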